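A Pyridin-3-yl Group in Place of Trifluoromethoxyphenyl

The compounds below may be only part of what the source reports. "The series", "measured", "known", "first", "only" and "open" are said of these compounds alone.

Of the compounds shown here, three sharing one core have been tested in an assay on CHO cells for displacement of a labelled ligand from adenosine receptor A1 (Homo sapiens), read by scintillation counting, with a stated time of 120 min, tested at 10 uM; on this read-out lower numbers stand for less inhibition and higher numbers for more inhibition at the one concentration tested (going by the name of the read-out). Compound 1 `Nc1scc(CN2CCN(c3ccc([N+](=O)[O-])cc3)CC2)c1C(=O)c1ccc(Cl)cc1` gives 1%. Compound 2 `Nc1scc(CN2CCN(c3ccccc3C(F)(F)F)CC2)c1C(=O)c1ccc(Cl)cc1` gives 0%, and compound 3 `Nc1scc(CN2CCN(c3ccc(OC(F)(F)F)cc3)CC2)c1C(=O)c1ccc(Cl)cc1` gives 0%. Compound 3 therefore stands level with compound 2 at the digits reported, the two together forming the lowest of the three numbers; the step of a number 1 percentage points lower from compound 1 to compound 3 (within the scatter) lies within the scatter, as do no change at the digits printed from compound 2 to compound 3 (within the scatter) and a number 1 percentage points lower from compound 1 to compound 2 (within the scatter). Compound 4 `Nc1scc(CN2CCN(c3cccnc3)CC2)c1C(=O)c1ccc(Cl)cc1` differs from compound 3 in one place: pyridin-3-yl in place of 4-(trifluoromethoxy)phenyl on an amine nitrogen in a ring. For the measured compounds named here, every measured step likewise exchanged one group on the amine nitrogen in the ring, and none of them moved the read-out in this assay beyond the scatter, which is the only guidance the data give for this exchange. Compound 4 is accordingly expected to remain at the same low level, with an expected step of a number 2 percentage points higher from compound 3 to compound 4 (within the scatter) in this assay that does not exceed the scatter. The estimate for compound 4 is 2%, with a range from -8% to 12%.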

Compound 4, a percentage reported as inhibition, at one concentration (the size of the read-out at that concentration, not a potency): 0%
For compound 4 the middle estimate is 2 percentage points above the measured one; the measured number falls inside the stated range.
By their numbers in this assay, from the lowest: compounds 2, 3, 4 and 1 (each within the scatter of the next).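

In this assay, pyridin-3-yl on the amine nitrogen in the ring gives no change at the digits printed from compound 3 to compound 4 (within the scatter), along with no change at the digits printed from compound 2 to compound 4 (within the scatter) and a number 1 percentage points lower from compound 1 to compound 4 (within the scatter). The earlier compounds shown here all carried a phenyl ring with a substituent at this position, so the flat read-out now also covers a six-membered aromatic ring with a hetero atom and fewer heavy atoms than 4-(trifluoromethoxy)phenyl. Nothing available explains why these exchanges leave the read-out unmoved.

The compounds shown leave open whether a non-aromatic group on this nitrogen, such as cyclohexyl or benzyl, would move the read-out beyond the scatter. They also leave open whether an exchange elsewhere on the shared core, such as a methoxy group in place of the chlorine, would do so.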